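A few compounds are considered here, and "the series" means these few. Any claim that something is new, unique, unknown or untested is made for them only; others in the source may bear on it.

In an ADME assay on HepG2 cells (Homo sapiens) for cytotoxicity, read by CellTiter-Glo and resazurin assay, with a stated time of 72 h (a higher number here means that more compound is needed for the effect, a lower number that less compound is needed), compound 3 `CC(C)N(Cc1cccc(OCCCCCC(=O)O)c1)C(=O)c1ccc(-c2ccc3cc[nH]c3c2)cc1` has no number, only a limit of the assay: > 26000 nM. Compound 1 `CC(C)COc1cccc(-c2ccc(C(=O)N(Cc3cccc(OCCCCCC(=O)O)c3)C(C)C)cc2)c1` also stands at a limit, > 26000 nM. Compound 2 `CC(C)N(Cc1cccc(OCCCCCC(=O)O)c1)C(=O)c1ccc(-c2cccc(OCc3ccccc3)c2)cc1` likewise gives only a limit, > 26000 nM.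

The next compound, compound 4 `CC(C)N(Cc1cccc(OCCCCCC(=O)O)c1)C(=O)c1ccc(-c2cccc(C(F)(F)F)c2)cc1`, differs from compound 3 at one place: 3-(trifluoromethyl)phenyl in place of 1H-indol-6-yl on an aromatic carbon. Here 3-(trifluoromethyl)phenyl stands in place of 1H-indol-6-yl on an aromatic carbon of a six-membered aromatic ring of carbon only, para to a large group.

Within the data shown here, two measured steps bear on this change. The closer one, made on an aromatic carbon as well, is a step that the two limits leave unreadable from compound 1 to compound 3. The other, made elsewhere in the molecule, is a step that the two limits leave unreadable from compound 1 to compound 2. Neither gives a size, so neither can set the size or direction of the new step. What remains is the limit of > 26000 nM in this assay, at which 3 of the 3 values shown sit, which takes in compound 1, compound 2 and compound 3 alike.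

In this assay, no step beyond the scatter is therefore expected, and no direction is favoured. The expected step is a step that the limit leaves unreadable from compound 3 to compound 4. Most likely the assay will again report only a limit. For compound 4 the estimate is 30000 nM, with an expected range from 15000 nM to 60000 nM.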

Compound 4, half-maximal effective concentration: > 26000 nM
Compound 4 gave a limit, no number; the forecaster's own chance of this, stated with the estimate: 85%; the middle value is on the limit's open side.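

Compound 4 gives only a limit in this assay, > 26000 nM. Its steps from compound 1, compound 2 and compound 3 cannot be read, and no size or direction follows for any of them. The compounds shown leave open whether these groups on the aromatic carbon differ at all in this assay.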